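Chalcone series: methoxy pattern on the aryl ketone

A few compounds are considered here, and "the series" means these few. Any claim that something is new, unique, unknown or untested is made for them only; others in the source may bear on it.

Measured compounds in a functional assay on DU-145 cells (Homo sapiens) for antiproliferative activity, read by MTT assay, with a stated time of 24 h; a lower number here means a stronger inhibitor, a higher number a weaker inhibitor:
compound 1 `COc1ccc(-c2cc(/C=C/C(=O)c3ccc(C)cc3)nc3cc(-c4ccccc4)nn23)cc1OC` gives 26800 nM
compound 2 `COc1cc(-c2cc(/C=C/C(=O)c3ccc(C)cc3)nc3cc(-c4ccccc4)nn23)cc(OC)c1OC` gives 27100 nM
compound 3 `COc1ccc(C(=O)/C=C/c2cc(-c3ccc(OC)c(OC)c3)n3nc(-c4ccccc4)cc3n2)cc1` gives 14600 nM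

The three values sit close together; the steps of a 1.0-fold higher number from compound 1 to compound 2 (0.00 log units; within the scatter) and a 1.8-fold lower number from compound 1 to compound 3 (0.26 log units; within the scatter) are both within the scatter. Compound 4 `COc1ccc(C(=O)/C=C/c2cc(-c3ccc(OC)c(OC)c3)n3nc(-c4ccccc4)cc3n2)cc1OC` is not yet measured. It differs from compound 3 by methoxy in place of hydrogen on an aromatic carbon. The same kind of change was made earlier, from compound 1 to compound 2, as methoxy in place of hydrogen on an aromatic carbon; there the place also reads meta to a methoxy group, which is absent around the place in compound 4, so the two changes are the same kind, not the same. The cores of compound 1 and compound 3 differ by methoxy in place of methyl on an aromatic carbon. Because a 1.0-fold higher number from compound 1 to compound 2 (0.00 log units; within the scatter) was flat, a step of about a 1.0-fold lower number from compound 3 to compound 4 (0.00 log units; within the scatter) is expected for compound 4. Compound 4 is estimated at 14500 nM, between 7000 nM and 30000 nM.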

Compound 4, half-maximal inhibitory concentration: 7200 nM
Estimate against measurement, compound 4: 2.0-fold (0.30 log units) above; measured number inside the range.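

In this assay, methoxy in place of hydrogen on an aromatic carbon gave a 2.0-fold lower number from compound 3 to compound 4 (0.31 log units; beyond the scatter), and 3,4-dimethoxyphenyl in place of 4-methylphenyl on a carbonyl carbon gave a 3.7-fold lower number from compound 1 to compound 4 (0.57 log units; beyond the scatter). Set beside the earlier case of the same change, the two steps cannot be told apart: the same change on two cores in this assay, a 1.0-fold higher number (0.00 log units; within the scatter) from compound 1 to compound 2 and a 2.0-fold lower number (0.31 log units; beyond the scatter) from compound 3 to compound 4, 2.1-fold (0.31 log units) apart, within the scatter of two such steps. For the compounds shown here, this gives no sign that the core alters the effect of the change, but it does not show that the change carries over unaltered, as there are only two pairs and the place of the added methoxy differs between them.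

The aryl ketone ring carries only methyl and methoxy groups in the compounds shown. Going by these compounds, how a fluorine, an amine or a carboxylic acid on that ring would behave stays open.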